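This account rests on a few compounds, and the source may have more. Where it says the series, first, only, none or still open, it means among the compounds named here.

Measured so far:
Compound 1, `O=C1NC(=O)/C(=C/c2cn(-c3ccccc3)nc2-c2ccc(Cl)cc2)S1`: 44%
Compound 2, `O=C1NC(=O)/C(=C/c2cn(-c3ccc([N+](=O)[O-])cc3)nc2-c2ccc(Cl)cc2)S1`: 51%

Both numbers come from a functional assay on the whole organism (strain Wistar albino) for inhibition, with Rattus norvegicus as the target, with stated times of 1 h and 7 days, at a dose of 20 mg/kg by the oral route; on this read-out lower numbers stand for less inhibition and higher numbers for more inhibition at the one dose given (going by the name of the read-out). Among the compounds with values here, compound 1 and compound 2 lie within the usual scatter of each other; the one measured step, a number 7 percentage points higher from compound 1 to compound 2 (within the scatter), is within the scatter. Compound 3, `C=CCN1C(=O)S/C(=C\c2cn(-c3ccccc3)nc2-c2ccc(Cl)cc2)C1=O`, is the next compound to be measured. It differs from compound 1 in one place: allyl in place of hydrogen on an amide-type nitrogen in a ring. Within the data shown here, the only measured step concerns a nitro group on an aromatic carbon of a different ring, so no measured step bears on a change at the amide-type nitrogen in the ring; the data give no step for that position. With nothing to point one way or the other, compound 3 is expected to give a number close to that of compound 1, that is, a step of a number 2 percentage points lower from compound 1 to compound 3 (within the scatter) not beyond the scatter. The estimate for compound 3 is 42%, with a range from 25% to 58%.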

Compound 3, a percentage reported as inhibition, in the whole organism at one dose (the size of the read-out at that dose, not a potency): 50%
Compound 3: the middle estimate sits 8 percentage points below what was measured; measured number inside the range.
By their numbers in this assay, from the lowest: compounds 1, 3 and 2 (each within the scatter of the next).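

Within the data shown here, this is the first measured change at the amide-type nitrogen in the ring. In this assay putting allyl in place of the hydrogen on that nitrogen gives a number 6 percentage points higher from compound 1 to compound 3 (within the scatter) and so shows that, at the one dose given, the amide hydrogen can be replaced by this chain without a step beyond the scatter. Nothing measured on these compounds offers an explanation for this result.

Still open, from the compounds shown here alone, is whether another group on this nitrogen, such as a methyl, a longer alkyl chain, a benzyl group or a chain ending in a carboxylic acid, would give a step beyond the scatter. Also open, going by these compounds, is how allyl on this nitrogen behaves together with the nitro group carried by compound 2.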